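This account rests on a few compounds, and the source may have more. Where it says the series, first, only, none or still open, it means among the compounds named here.

Compound 1 `COC1Cc2sccc2C2(CCN(CCC(C)C)CC2)O1` is the starting point. In an assay on membranes from brain for displacement of a labelled ligand from Sigma non-opioid intracellular receptor 1 (Cavia porcellus) (on this read-out higher numbers stand for weaker inhibition and lower numbers for stronger inhibition), compound 1 gives 1 nM. Of the three measured compounds, compound 3 `COC1Cc2sccc2C2(CCN(Cc3ccc(F)cc3)CC2)O1`, which gives 0.62 nM, lies within the scatter of compound 1, while compound 2 `COC1Cc2sccc2C2(CCNCC2)O1`, with 602 nM, lies far from it: a 600-fold higher number from compound 1 to compound 2 (2.78 log units; beyond the scatter).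

Compound 4 `CCCCN1CCC2(CC1)OC(OC)Cc1sccc12` differs from compound 1 by hydrogen in place of methyl on a saturated chain carbon bound to two saturated chain carbons. For the measured compounds named here, two steps bear on this. Stripping the whole group from the ring nitrogen cost a great deal, a 600-fold higher number from compound 1 to compound 2 (2.78 log units; beyond the scatter), but exchanging one group for another at that nitrogen changed little: a 1.6-fold lower number from compound 1 to compound 3 (0.21 log units; within the scatter). Shortening the chain by one carbon while keeping a group on the nitrogen is therefore expected to give a step no larger than the scatter, a 1.5-fold higher number from compound 1 to compound 4 (0.18 log units; within the scatter). Compound 4 is estimated at 1.5 nM, between 0.5 nM and 5 nM.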

Compound 4, inhibition constant: 4.3 nM
The estimate for compound 4 lay 2.9-fold (0.46 log units) below the measured number; low and high end bracket the measured number.
By their numbers in this assay, from the lowest: compounds 3 and 1 (each within the scatter of the next); then compound 4; then compound 2.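

In this assay, losing the methyl that turns isopentyl into butyl is a real change (a step of a 4.3-fold higher number from compound 1 to compound 4 (0.63 log units; beyond the scatter)), so the end of the chain on the amine nitrogen in a ring matters even when a group stays there. Butyl also falls behind 4-fluorobenzyl (a 6.9-fold higher number from compound 3 to compound 4 (0.84 log units; beyond the scatter)), yet it remains far better than hydrogen (a 140-fold lower number from compound 2 to compound 4 (2.15 log units; beyond the scatter)). Nothing available explains these differences. As far as these compounds go, whether propyl would lose more, or hexyl would recover the loss, stays open.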